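Swapping Methoxycarbonyl for Acetamido on a Shared Core

The source may report more compounds than this note shows. Statements on the series, on what has been measured and on what is new or still open speak of the compounds shown alone.

Three measured compounds share a core and differ in one group on an aromatic carbon. In a toxicity assay on CCRF-CEM cells (Homo sapiens) for cytotoxicity (on this read-out lower numbers stand for higher toxicity in this test and higher numbers for lower toxicity in this test), compound 1 `Cc1cccc2c1nc(-c1c(F)cccc1F)n2Cc1c(F)cccc1F` gives > 100 uM, which is a limit of the assay and not a number. Compound 2 `COC(=O)c1cccc2c1nc(-c1c(F)cccc1F)n2Cc1c(F)cccc1F` reads 57.7 uM, and compound 3 `Nc1cccc2c1nc(-c1c(F)cccc1F)n2Cc1c(F)cccc1F` reads 26.3 uM. Compound 2 therefore holds the higher of the two actual numbers, and the gap to its nearest neighbour is a 2.2-fold lower number from compound 2 to compound 3 (0.34 log units; beyond the scatter).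

Compound 4 `CC(=O)Nc1cccc2c1nc(-c1c(F)cccc1F)n2Cc1c(F)cccc1F` has not been measured. It differs from compound 2 by one change: acetamido in place of methoxycarbonyl on an aromatic carbon. Two other steps start from the limit, so each gives only a minimum size: an at least 1.7-fold lower number from compound 1 to compound 2 (0.23 log units; that floor lies within the scatter) and an at least 3.8-fold lower number from compound 1 to compound 3 (0.58 log units; beyond the scatter). The most useful guide is the modest step between the two actual numbers. Acetamido has a carbonyl, as does the methoxycarbonyl of compound 2 at 57.7 uM, and a nitrogen on the aromatic carbon, as does the amino group of compound 3 at 26.3 uM. A result near these two values therefore seems likely, with no change beyond the scatter expected. The expected change is a 1.2-fold lower number from compound 2 to compound 4 (0.06 log units; within the scatter). For compound 4 the estimated value is 50 uM, with an expected range of 22 uM to 100 uM.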

Compound 4, half-maximal toxic concentration: 39.3 uM
Estimate against measurement, compound 4: 1.3-fold (0.10 log units) above; low and high end bracket the measured number.
By their numbers in this assay, from the lowest: compounds 3, 4 and 2 (each within the scatter of the next, the first and the last beyond it). At a limit, above all of these: compound 1.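

In this assay, the swap of methoxycarbonyl for acetamido gives a 1.5-fold lower number from compound 2 to compound 4 (0.17 log units; within the scatter), and adding acetyl to the nitrogen of the amino group gives a 1.5-fold higher number from compound 3 to compound 4 (0.17 log units; within the scatter). Compound 2 and compound 3 lie beyond the scatter of each other, yet compound 4 lies within the scatter of both, so at this position neither replacing the carbonyl-bearing ester with an amide attached through nitrogen nor acylating the amino group moves the number measurably. The methyl group remains the one clear contrast, with an at least 2.5-fold lower number from compound 1 to compound 4 (0.40 log units; beyond the scatter) giving only a minimum size, since compound 1 sits at a limit of the assay and not at a number: the limit of > 100 uM in this assay, at which 1 of the 4 values shown sits.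

On these data alone, whether a longer chain on the amide, such as propanoyl, would stay in this same range remains open, as does the result for a carboxylic acid or a dimethylamino group on this aromatic carbon. All the compounds shown also keep the rest of the shared core unchanged, so it is unknown whether this pattern would hold with a different group elsewhere on that core.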